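Working notes: from compound 3 to compound 4

The source may hold more compounds than are shown below. What is called first, only, known or untested is meant among the compounds shown, and "the series" means these compounds.

Values measured in a functional assay on HL-60 cells (Homo sapiens) for inhibition, read by MTT assay, with a stated time of 48 h, tested at 10 uM (a lower number here means less inhibition of growth, a higher number more inhibition of growth at the concentration tested), stand as follows:
compound 1 `Cc1cc(=O)c2c(O)cc(OCc3ccccc3Br)c([C@H]3CCN(C)C[C@H]3O)c2o1` gives 3%
compound 2 `Cc1cc(=O)c2c(O)c(CN(C)CC(=O)O)c(O)c([C@H]3CCN(C)C[C@H]3O)c2o1` gives 23%
compound 3 `Cc1oc2c([C@H]3CCN(C)C[C@H]3O)c(O)cc(O)c2c(=O)c1C(O)c1ccc(Cl)cc1` gives 2%

Compound 3 at 2% cannot be told apart from compound 1. Compound 2 gives 23% in this assay. The gap that separates compound 2 from compound 1 and from compound 3 is larger than the scatter on these three numbers.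

The next compound, compound 4 `Cc1oc2c([C@H]3CCN(C)C[C@H]3O)c(O)cc(O)c2c(=O)c1C(O)c1ccc(F)c(Br)c1`, carries 3-bromo-4-fluorophenyl in place of 4-chlorophenyl on a saturated chain carbon bound to an aromatic carbon and an oxygen on a saturated carbon and is otherwise the same as compound 3.

Among the measured compounds shown here, no measured pair differs in one place only, so the data do not show what an exchange of this kind does. With compound 3 at 2% as the only anchor, no step beyond the scatter is expected in this assay and any movement is expected to be slightly upward. The estimate is a number 4 percentage points higher from compound 3 to compound 4 (within the scatter) and it stays within the scatter.

Compound 4 is expected at 6% with an estimated range of 0% to 18% in this assay once measured.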

Compound 4, percent growth inhibition at one concentration: 25%
For compound 4 the middle estimate is 19 percentage points below the measured one; the whole stated range lies below it.
By their numbers in this assay, from the lowest: compounds 3 and 1 (each within the scatter of the next); then compounds 2 and 4 (each within the scatter of the next).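

In this assay, among the compounds shown here, the exchange of 4-chlorophenyl for 3-bromo-4-fluorophenyl gives a number 23 percentage points higher from compound 3 to compound 4 (beyond the scatter), the first comparison that differs in one place only. This shows that the number is sensitive to the aryl group on this saturated chain carbon, even though both groups are a six-membered aromatic ring of carbon only, with no hydrogen-bond donors or acceptors and no net charge. No measurement shown bears on why the number moves.

Chlorine leaves and both bromine and fluorine enter in this one exchange, so it remains open whether bromine alone or fluorine alone would give a step of this size. Also open, on these data alone, is what an amine or a carboxylic acid on this phenyl ring would do.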